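This account rests on a few compounds, and the source may have more. Where it says the series, first, only, none or still open, it means among the compounds named here.

Measured compounds and their values:

Compound 1, `CNC(=O)CC1CCc2cc(OC)c(OC)cc21`: 33.3%
Compound 2, `CCCCCCNC(=O)CC1CCc2cc(OC)c(OC)cc21`: 45.5%
Compound 3, `COc1cc2c(cc1OC)C(CC(=O)NC1CCCC1)CC2`: 46.7%

In a functional assay on the whole organism (strain Wistar) for inhibition, with Rattus norvegicus as the target, read by paw edema, with stated times of 60 min and 24 h, at a dose of 100 mg/kg by the oral route (on this read-out lower numbers stand for less inhibition and higher numbers for more inhibition at the one dose given (going by the name of the read-out)), compound 3 gives 46.7%, the largest of the three numbers. Its gap to compound 2 is small, a number 1.2 percentage points higher from compound 2 to compound 3 (within the scatter), so the two cannot be told apart on this read-out; only compound 1 sits clearly lower, as a number 13.4 percentage points higher from compound 1 to compound 3 (beyond the scatter) shows.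

The untested compound 4, `COc1cc2c(cc1OC)C(CC(=O)N1CCOCC1)CC2`, differs from compound 3 in one place: morpholin-4-yl in place of cyclopentylamino on a carbonyl carbon. The amide hydrogen of compound 3 is thus gone, and a ring holding nitrogen and oxygen takes the place of the carbon ring.

Every measured step also alters the group on the amide nitrogen. Going from a small group to a larger one gave modest gains, a number 12.2 percentage points higher from compound 1 to compound 2 (beyond the scatter) and a number 13.4 percentage points higher from compound 1 to compound 3 (beyond the scatter), while swapping one larger group for another of like size gave a number 1.2 percentage points higher from compound 2 to compound 3 (within the scatter). Going by the values given here, no measured step removes the amide hydrogen, so that part of the change has no precedent here. The entering group is close in size to the one leaving, which points to a step of little size; the loss of the amide hydrogen adds uncertainty. The step from compound 3 is therefore expected to be a number 7.7 percentage points lower from compound 3 to compound 4 (within the scatter), not beyond the scatter. Compound 4 is estimated at 39%, within 24% to 53%.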

Compound 4, a percentage reported as inhibition, in the whole organism at one dose (the size of the read-out at that dose, not a potency): 23.3%
For compound 4 the middle estimate is 15.7 percentage points above the measured one; measured number outside the range, below it.
By their numbers in this assay, from the lowest: compounds 4 and 1 (each within the scatter of the next); then compounds 2 and 3 (each within the scatter of the next).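

Morpholin-4-yl and cyclopentylamino have the same number of heavy atoms on the carbonyl carbon, yet this assay records a number 23.4 percentage points lower from compound 3 to compound 4 (beyond the scatter) and also a number 22.2 percentage points lower from compound 2 to compound 4 (beyond the scatter) when hexylamino is the group replaced, so the size of the group alone does not set the number at this position. The earlier gain seen on moving from methylamino to a larger group does not hold for morpholin-4-yl, the one listed group that goes against it: the result is a number 10 percentage points lower from compound 1 to compound 4 (within the scatter) and compound 4 cannot be told apart from compound 1. This swap removes the amide hydrogen and brings in a ring oxygen together, and no measurement at hand explains the fall or separates these two changes.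

The compounds shown leave open which of the two changes matters more. Piperidin-1-yl, a six-membered carbon ring joined through its nitrogen with no amide hydrogen, and tetrahydropyran-4-ylamino, which keeps the amide hydrogen and carries a ring oxygen, would pull the two apart.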